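The source may report more compounds than this note shows. Statements on the series, on what has been measured and on what is new or still open speak of the compounds shown alone.

Measured in an assay on CHO cells for inhibition of Glucagon receptor (Homo sapiens); on this read-out lower numbers stand for stronger inhibition and higher numbers for weaker inhibition:
Compound 1, `CCCCCc1c(C(C)C)nc(C(C)C)c(CO)c1-c1ccc(F)c(F)c1`, gives 1100 nM.
Compound 2, `CCCCCc1c(C(C)C)nc(C(C)C)c(CO)c1-c1cccc(O)c1`, gives 6000 nM.
Compound 3, `CCCCCc1c(C(C)C)nc(C(C)C)c(CO)c1-c1ccccc1O`, gives 500 nM.

Compound 3 has the lowest number of the three, since the steps of a 2.2-fold lower number from compound 1 to compound 3 (0.34 log units; beyond the scatter) and a 12-fold lower number from compound 2 to compound 3 (1.08 log units; beyond the scatter) both lie beyond the scatter. Compound 4, `CCCCCc1c(C(C)C)nc(C(C)C)c(CO)c1-c1ccc(F)c(CO)c1`, differs from compound 3 by 4-fluoro-3-(hydroxymethyl)phenyl in place of 2-hydroxyphenyl on an aromatic carbon. Among the measured compounds shown here, no measured step covers this exact exchange. For the measured compounds named here, two steps bear on it: a 2.2-fold lower number from compound 1 to compound 3 (0.34 log units; beyond the scatter) shows the 2-hydroxyphenyl ahead of a fluorinated ring by a modest margin, and a 12-fold lower number from compound 2 to compound 3 (1.08 log units; beyond the scatter) shows it ahead of 3-hydroxyphenyl by a large one. Compound 4 keeps a fluorine, as compound 1 does, and a hydroxyl-bearing group, as compound 2 does, but gives up the 2-hydroxyphenyl, so a higher number in this assay is expected, probably between those two steps. Compound 4 is therefore estimated at 2000 nM, in the range 600 nM to 7000 nM. This expected change amounts to a 4.0-fold higher number from compound 3 to compound 4 (0.60 log units; beyond the scatter).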

Compound 4, half-maximal inhibitory concentration: 19000 nM
Compound 4: the middle estimate sits 9.5-fold (0.98 log units) below what was measured; measured number above the stated range.
By their numbers in this assay, from the lowest: compound 3; then compound 1; then compound 2; then compound 4.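

In this assay, exchanging fluoro for hydroxymethyl on the phenyl ring gives a 17-fold higher number from compound 1 to compound 4 (1.24 log units; beyond the scatter), so a hydroxyl-bearing group here does not by itself lower the number. The 4-fluoro-3-(hydroxymethyl)phenyl group also trails both hydroxyphenyl groups, with a 3.2-fold higher number from compound 2 to compound 4 (0.50 log units; beyond the scatter) and a 38-fold higher number from compound 3 to compound 4 (1.58 log units; beyond the scatter), making 2-hydroxyphenyl the only hydroxyl-bearing group shown that beats the difluorophenyl group. The data offer no measurement that explains these differences. On these data alone, whether 2-aminophenyl or 2-methoxyphenyl would match 2-hydroxyphenyl remains open, as does the effect of adding fluoro to the 2-hydroxyphenyl ring.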